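The compounds below may be only part of what the source reports. "The series", "measured", "known", "first", "only" and "open" are said of these compounds alone.

The shared core carries a carboxy group or its replacement on one ring and a small substituent on the other. Compound 1 `CCc1cccc2cc(C(=O)O)cnc12` in a functional assay on the whole organism (strain Sprague-Dawley) for inhibition, with Rattus norvegicus as the target (a higher number here means that more compound is needed for the effect, a lower number that less compound is needed), gives 75 mg/kg. Compound 2 `Cc1cccc2cc(C(=O)O)cnc12` in this assay reaches only the limit of the assay, > 25 mg/kg, and not a number. The step that the limit leaves unreadable from compound 1 to compound 2 is therefore not readable, which follows from the limit of > 25 mg/kg in this assay, at which 1 of the 3 values shown sits. Compound 3 `Cc1cccc2cc(-c3nn[nH]n3)cnc12` in this assay gives 25 mg/kg, and the step of a number no higher from compound 2 to compound 3 (the limit leaves the size open) is likewise left open in size. Compound 2 thus stands as a limit only, with no number of its own among the three values shown.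

Compound 4 `CCOc1cccc2cc(C(=O)O)cnc12` differs from compound 2 by ethoxy in place of methyl on an aromatic carbon. Among the compounds with values here, no measured step covers an exchange of this kind: the step from compound 1 to compound 2 changes the chain bound to the aromatic carbon and is unreadable, and the step from compound 2 to compound 3 alters the other group. Within the data shown here, the only anchor is compound 1, which carries ethyl at that aromatic carbon, with its value 75 mg/kg. Compound 4 is therefore expected to give about 75 mg/kg in this assay, between 25 mg/kg and 200 mg/kg. The step that the limit leaves unreadable from compound 2 to compound 4 is expected to be small, though it cannot be sized against a limit.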

Compound 4, minimum effective dose: > 50 mg/kg
Compound 4: only a limit was reported; the forecaster's own chance of this, stated with the estimate: 30%; the middle value does not contradict the limit.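

Compound 4 in this assay reaches only a limit, > 50 mg/kg, and not a number. No step from compound 1 or compound 2 to compound 4 can be read, which follows from this limit: the limit of > 50 mg/kg in this assay, at which 1 of the 4 values shown sits.

The compounds shown leave open whether ethoxy in place of methyl or ethyl on an aromatic carbon changes the minimum effective dose at all.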